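One Added Fluoro on Compound 1

The source may report more compounds than this note shows. Statements on the series, on what has been measured and on what is new or still open speak of the compounds shown alone.

In a functional assay on HeLa cells (Homo sapiens) for inhibition, read by CCK-8 assay, with a stated time of 72 h, tested at 10 uM (on this read-out higher numbers stand for more inhibition of growth at the one concentration tested and lower numbers for less inhibition of growth), compound 1 (`CN(C)C(=O)c1cc2cnc(Nc3ccc(NC(=O)C4(C(=O)Nc5ccc(F)cc5)CC4)cc3)nc2n1C1CCCC1`) gives 73.7% as the lower of two measured numbers, while compound 2 (`CN(C)C(=O)c1cc2cnc(Nc3ccc(NC(=O)C4(C(=O)Nc5cccc(O)c5)CC4)cc3)nc2n1C1CCCC1`) gives 96.6% as the higher. Compound 3 (`CN(C)C(=O)c1cc2cnc(Nc3ccc(NC(=O)C4(C(=O)Nc5ccc(F)cc5)CC4)cc3F)nc2n1C1CCCC1`) differs from compound 1 by one small change (fluoro in place of hydrogen on an aromatic carbon) with fluoro in place of hydrogen on an aromatic carbon, ortho to a large group and meta to a large group. For the measured compounds named here, the one measured step (a number 22.9 percentage points higher from compound 1 to compound 2 (beyond the scatter)) puts 3-hydroxyphenyl in place of 4-fluorophenyl on an amide-type nitrogen. Going by the values given here, that is another place in the molecule, so this modest step bears only loosely on the new change, and no step at this carbon has been measured. No step beyond the scatter is therefore expected in this assay and neither direction is favoured. The estimated step (a number 1.3 percentage points higher from compound 1 to compound 3 (within the scatter)) stays small. Compound 3 is expected at 75% within an estimated range of 52% to 93% for now.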

Compound 3, percent growth inhibition at one concentration: 49.5%
The estimate for compound 3 lay 25.5 percentage points above the measured number; the measured number lies below the stated range.
By their numbers in this assay, from the lowest: compound 3; then compound 1; then compound 2.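

In this assay, fluoro in place of hydrogen on this aromatic carbon gives a number 24.2 percentage points lower from compound 1 to compound 3 (beyond the scatter), so a change of one heavy atom here is enough to carry the number beyond the scatter. For the compounds shown here, this is the first step measured at this carbon, and it runs downward, whereas the change at another place in the molecule, on the amide-type nitrogen, gave a number 22.9 percentage points higher from compound 1 to compound 2 (beyond the scatter). Nothing measured here explains the drop.

The compounds shown leave open whether the drop belongs to fluoro itself or would also follow other groups on this carbon, such as chloro, methoxy or an amine. They also leave open whether the same fluoro would lower the number to a similar extent with 3-hydroxyphenyl in place of 4-fluorophenyl on the amide-type nitrogen.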